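Taking the nitro group off compound 3

This account rests on a few compounds, and the source may have more. Where it says the series, first, only, none or still open, it means among the compounds named here.

Notes on the series start from the core of compound 1 (`Cc1nc(-c2cccnc2)sc1-c1nnc(Cc2ccccc2)o1`), carried also by compound 2 (`Cc1nc(-c2cccnc2)sc1-c1nnc(-c2ccc(Br)cc2)o1`), compound 3 (`Cc1nc(-c2cccnc2)sc1-c1nnc(-c2ccc([N+](=O)[O-])cc2)o1`) and the unmeasured compound 4 (`Cc1nc(-c2cccnc2)sc1-c1nnc(-c2ccccc2)o1`).

In an ADME assay on HCT-116 cells (Homo sapiens) for cytotoxicity, read by MTT assay (on this read-out higher numbers stand for lower toxicity in this test and lower numbers for higher toxicity in this test), compound 1 gives > 100 ug/mL, which is a limit and not a number. Compound 2 gives > 100 ug/mL, which is also a limit. Compound 3 gives > 100 ug/mL, again a limit, so its place in the series has no number. The whole set rests on (the limit of > 100 ug/mL in this assay, at which 3 of the 3 values shown sit).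

The next change puts hydrogen in place of nitro on an aromatic carbon, para to a large group: hydrogen in place of nitro on an aromatic carbon.

Going by the values given here, two measured steps bear on it. Among the compounds with values here, the first is a step that the two limits leave unreadable from compound 1 to compound 2. The closer one, which also changes the group at this place, is a step that the two limits leave unreadable from compound 2 to compound 3. Neither gives a size, so no direction can be drawn from them, and a shift beyond the usual scatter is not expected in this assay. The estimated step is a step that the limit leaves unreadable from compound 3 to compound 4. Compound 4 is expected to be reported most likely as a limit too. For compound 4 the estimate is 130 ug/mL, with an expected range from 65 ug/mL to 260 ug/mL.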

Compound 4, half-maximal cytotoxic concentration: > 100 ug/mL
Compound 4 was reported as a limit; the forecaster's own chance of this, stated with the estimate: 85%; the middle value is on the limit's open side.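

No new step can be read: compound 4, like compound 1, compound 2 and compound 3, is reported only as a limit in this assay, and the steps among them have no readable size: the limit of > 100 ug/mL in this assay, at which 4 of the 4 values shown sit.

The compounds shown leave open whether any group at this place on the shared core gives a numerical value in this assay.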